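The source may report more compounds than this note shows. Statements on the series, on what has been measured and on what is new or still open speak of the compounds shown alone.

Compound 1 `C=CCCC(=O)N1CC(CC=C)C1=O` gives 96.5%.
Compound 2 `C=CCCCC1CN([Si](C)(C)C(C)(C)C)C1=O` gives 76.9%.
Compound 3 `C=CCCCC1CN(C(=O)CCC=C)C1=O` gives 101%.

All three were tested in an assay for inhibition of Fatty-acid amide hydrolase 1 (Homo sapiens), tested at 1 mM; on this read-out lower numbers stand for less inhibition and higher numbers for more inhibition at the one concentration tested (going by the name of the read-out). Compound 3 and compound 1 share a core and differ in a single place: vinyl in place of but-3-en-1-yl on a saturated chain carbon bound to a saturated ring carbon. This change produced a number 4.5 percentage points lower from compound 3 to compound 1 (within the scatter), so the two values show no real difference between them. Compound 2 has the lowest number of the three, and the difference between its core and the core of compound 3 is not broken down here. Compound 4 `C=CCC1CN([Si](C)(C)C(C)(C)C)C1=O` has not yet been measured; it differs from compound 2 by vinyl in place of but-3-en-1-yl on a saturated chain carbon bound to a saturated ring carbon, the same change as that between compound 3 and compound 1. The step from compound 2 to compound 4 in this assay is expected to be about a number 4.9 percentage points lower from compound 2 to compound 4 (within the scatter), because the matching step a number 4.5 percentage points lower from compound 3 to compound 1 (within the scatter) stayed within the scatter. Compound 4 is therefore estimated to give 72%, most likely between 55% and 88%.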

Compound 4, a percentage reported as inhibition, at one concentration (the size of the read-out at that concentration, not a potency): 43.6%
The estimate for compound 4 lay 28.4 percentage points above the measured number, outside the stated range (below it).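

In this assay, putting vinyl in place of but-3-en-1-yl gave a number 33.3 percentage points lower from compound 2 to compound 4 (beyond the scatter), so this change did not carry the same size of step from one core to the other: the same change on two cores in this assay, a number 4.5 percentage points lower (within the scatter) from compound 3 to compound 1 and a number 33.3 percentage points lower (beyond the scatter) from compound 2 to compound 4, 28.8 percentage points apart, beyond the scatter of two such steps

A small step on the core of compound 3 therefore gave no safe guide to the step on the core of compound 2. These two pairs do not show why the cores respond differently, and they set no rule for any other core.

The compounds shown leave open what a longer chain, an amine or a carboxylic acid in place of but-3-en-1-yl would give on either core. They also leave open whether other changes at this place would differ between the two cores in the same way.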